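Nitro Replaces Formyl on the Sulfonyl Substituent

A few compounds are considered here, and "the series" means these few. Any claim that something is new, unique, unknown or untested is made for them only; others in the source may bear on it.

Of the compounds shown here, three sharing one core have been tested in a functional assay on HepG2 cells (Homo sapiens) for antiproliferative activity, with a stated time of 72 h; a higher number here means that more compound is needed for the effect, a lower number that less compound is needed. Compound 1 `COc1ccc(-c2cc(=O)c3c(OC)cc(OC)cc3[nH]2)cc1` carries a hydrogen on its aromatic nitrogen. In this assay compound 1 gives > 31100 nM, which is a limit of the assay and not a number. Compound 2 `COc1ccc(-c2cc(=O)c3c(OC)cc(OC)cc3n2Cc2ccccc2)cc1` carries a benzyl group on that nitrogen. In this assay compound 2 gives > 17300 nM, again a limit rather than a number. Compound 3 `COc1ccc(-c2cc(=O)c3c(OC)cc(OC)cc3n2S(=O)(=O)c2ccc(C=O)cc2)cc1` carries a (4-formylphenyl)sulfonyl group on the aromatic nitrogen. In this assay compound 3 gives > 34400 nM, which is also a limit. All three values sit at limits, as the limit of > 17300 nM in this assay, at which 1 of the 3 values shown sits, the limit of > 31100 nM in this assay, at which 1 of the 3 values shown sits, and the limit of > 34400 nM in this assay, at which 1 of the 3 values shown sits, record, so the steps a step that the two limits leave unreadable from compound 1 to compound 2, a step that the two limits leave unreadable from compound 1 to compound 3 and a step that the two limits leave unreadable from compound 2 to compound 3 cannot be read in size or direction, and compound 3 cannot be placed above or below the other two.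

Compound 4 `COc1ccc(-c2cc(=O)c3c(OC)cc(OC)cc3n2S(=O)(=O)c2ccc([N+](=O)[O-])cc2)cc1` has not yet been measured. It differs from compound 3 in one place: nitro in place of formyl on an aromatic carbon. Going by the values given here, none of the measured steps has a readable size, so they give no ground to expect a step beyond the scatter in either direction in this assay. The expected step is a step that the limit leaves unreadable from compound 3 to compound 4. Compound 4 is therefore expected to give 40000 nM, within a range from 15000 nM to 150000 nM, and most probably the assay will again report only a limit.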

Compound 4, half-maximal effective concentration: > 29300 nM
Compound 4: only a limit was reported (the forecaster's own chance of this, stated with the estimate: 85%); the middle value is on the limit's open side.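

Compound 4 gives > 29300 nM, which is a limit of the assay and not a number. Compound 3 also stands only at a limit, so the step from compound 3 to compound 4 cannot be read in size or direction. The compounds shown leave open whether any group on the aromatic nitrogen of the shared core gives a measurable value in this assay.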